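Adding a Second Trifluoromethyl Group to a Benzamide Sulfonamide

The compounds below may be only part of what the source reports. "The series", "measured", "known", "first", "only" and "open" are said of these compounds alone.

Compound 1 `Cc1cc(NC(=O)c2cc(C(F)(F)F)cc(C(F)(F)F)c2)ccc1NS(C)(=O)=O` gives > 250000 nM in an ADME assay on RAW264.7 cells (Mus musculus) for cytotoxicity, read by MTT assay, with a stated time of 48 h; a lower number here means a stronger inhibitor, a higher number a weaker inhibitor; this is a limit of the assay, not a number.
Compound 2 `CS(=O)(=O)Nc1ccc(NC(=O)c2cccc(C(F)(F)F)c2)cc1F` gives 32300 nM in this assay.

Among the compounds with values here, compound 2 carries the only actual number among the values shown; the other value, that of compound 1, sits at the limit of > 250000 nM in this assay, at which 1 of the 2 values shown sits. Compound 3 `CS(=O)(=O)Nc1ccc(NC(=O)c2cc(C(F)(F)F)cc(C(F)(F)F)c2)cc1F` differs from compound 2 by trifluoromethyl in place of hydrogen on an aromatic carbon, a trifluoromethyl in place of hydrogen on an aromatic carbon. The two measured compounds differ in more than one place, so their values cannot be read as a single step. Still, compound 1 also carries two trifluoromethyl groups on the same ring and sits at the limit of > 250000 nM in this assay, at which 1 of the 2 values shown sits. On that basis compound 3 is expected to be a weaker inhibitor than compound 2 in this assay, by a step beyond the usual scatter, a 3.7-fold higher number from compound 2 to compound 3 (0.57 log units; beyond the scatter). Compound 3 is estimated at 120000 nM, within 40000 nM to 250000 nM, and a result reported only as a limit would not be surprising.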

Compound 3, half-maximal inhibitory concentration: 125000 nM
For compound 3 the middle estimate is 1.0-fold (0.02 log units) below the measured one; the range from low to high includes it.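

With a number for compound 3, the second trifluoromethyl group can now be read as a single change in this assay: in place of hydrogen on an aromatic carbon, it gives a 3.9-fold higher number from compound 2 to compound 3 (0.59 log units; beyond the scatter), a modest step toward weaker cytotoxicity. Fluoro in place of methyl on an aromatic carbon, with both trifluoromethyl groups kept, gives an at least 2.0-fold lower number from compound 1 to compound 3 (0.30 log units; that floor lies within the scatter), so this comparison does not establish a real difference between the two compounds. Compound 1 remains a limit of the assay, not a number: the limit of > 250000 nM in this assay, at which 1 of the 3 values shown sits.

Going by these compounds, only hydrogen and trifluoromethyl can be compared at this position, so it remains open how a chlorine atom, a methoxy group or an amine would behave there. The compounds shown also give no measured property that could explain the step.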